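The source may hold more compounds than are shown below. What is called first, only, known or untested is meant among the compounds shown, and "the series" means these compounds.

Three compounds share one core and differ in the group on a carbon with a double bond to nitrogen. In a functional assay on A549 cells (Homo sapiens) for cytotoxicity, read by MTT assay, with a stated time of 72 h (on this read-out lower numbers stand for stronger inhibition and higher numbers for weaker inhibition), compound 1 (`COc1cc2ncnc(Nc3ccc(F)c(Cl)c3)c2cc1NC(=O)N/N=C/c1ccc(C#N)cc1`) gives 32200 nM, compound 2 (`COc1cc2ncnc(Nc3ccc(F)c(Cl)c3)c2cc1NC(=O)N/N=C/c1ccc([N+](=O)[O-])cc1`) gives 35100 nM and compound 3 (`COc1cc2ncnc(Nc3ccc(F)c(Cl)c3)c2cc1NC(=O)N/N=C/c1ccc(F)cc1Cl`) gives 28200 nM. Compound 3 therefore stands level with the other two, since neither of them lies beyond the scatter from it.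

Compound 4 (`COc1ccc(/C=N/NC(=O)Nc2cc3c(Nc4ccc(F)c(Cl)c4)ncnc3cc2OC)cc1`) changes the same place: 4-methoxyphenyl in place of 2-chloro-4-fluorophenyl on a carbon with a double bond to nitrogen. That is, 4-methoxyphenyl stands in place of 2-chloro-4-fluorophenyl on a carbon with a double bond to nitrogen.

For the measured compounds named here, three measured steps bear on this change. Two swap the whole group at this place, a 1.1-fold lower number from compound 1 to compound 3 (0.06 log units; within the scatter) and a 1.2-fold lower number from compound 2 to compound 3 (0.10 log units; within the scatter), while the third alters only the group's substituent, a 1.1-fold higher number from compound 1 to compound 2 (0.04 log units; within the scatter). All three are small and lie within the scatter, so this place has shown no sensitivity so far. Going by the values given here, none of them brings in a methoxy group, however, and the data hold no direct precedent for 4-methoxyphenyl. No step beyond the scatter is therefore expected in this assay, and no direction is favoured. The expected change is a 1.1-fold higher number from compound 3 to compound 4 (0.03 log units; within the scatter). For compound 4 the estimated value is 30000 nM, within an expected range of 14000 nM to 60000 nM.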

Compound 4, half-maximal inhibitory concentration: 28100 nM
Compound 4: the middle estimate sits 1.1-fold (0.03 log units) above what was measured; the range from low to high includes it.
By their numbers in this assay, from the lowest: compounds 4, 3, 1 and 2 (each within the scatter of the next).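

Compound 4 puts a methoxy group at this position for the first time among the compounds shown, and in this assay the exchange of 2-chloro-4-fluorophenyl for 4-methoxyphenyl gives a 1.0-fold lower number from compound 3 to compound 4 (0.00 log units; within the scatter). Read on the substituent alone, methoxy in place of nitro gives a 1.2-fold lower number from compound 2 to compound 4 (0.10 log units; within the scatter) and methoxy in place of cyano gives a 1.1-fold lower number from compound 1 to compound 4 (0.06 log units; within the scatter), so the insensitivity seen among compounds 1, 2 and 3 now extends to a fourth aryl group, and no step among the four compounds leaves the scatter. The entering group counts a hydrogen-bond acceptor where the leaving group counts none, yet nothing presented here offers an explanation for this flat response.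

From the compounds shown here alone, all four compounds carry a substituted phenyl on the carbon with a double bond to nitrogen, so it remains open whether the same flatness would hold with an amine or a carboxylic acid on that ring, or with a longer alkyl chain in place of the ring. The shared core is the same throughout, which leaves open how far changes elsewhere on it would move these numbers.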